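This account rests on a few compounds, and the source may have more. Where it says the series, first, only, none or still open, it means among the compounds named here.

Measured so far:
Compound 1 `CN1CCC[C@H]1COc1cnccc1Br` gives 17%.
Compound 2 `Cc1cncc(OC[C@@H]2CCCN2C)c1` gives 78.8%.

Both numbers come from an assay on IMR-32 cells with Neuronal acetylcholine receptor; alpha4/beta2 (Homo sapiens) as the target; on this read-out higher numbers stand for larger maximal responses and lower numbers for smaller maximal responses. For the measured compounds named here, of the two, compound 2 holds the higher value; its only neighbour, compound 1, lies far below it, a gap beyond the scatter. Compound 3 `CCc1cncc(OC[C@@H]2CCCN2C)c1` has not yet been measured. It differs from compound 2 in a single place: methyl in place of hydrogen on a saturated chain carbon bound to an aromatic carbon. Going by the values given here, no pair of measured compounds shows what this kind of change does here, so the expectation rests on compound 2 alone. Going from methyl to ethyl is a small alteration, and for compound 3 a modest step is expected, if anything slightly downward and quite possibly within the scatter: a number 8.8 percentage points lower from compound 2 to compound 3 (within the scatter). Compound 3 is therefore estimated to give 70% in this assay, with a likely range from 45% to 90%.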

Compound 3, largest response reached (reported as maximum), in percent of the reference or control that the assay uses: 15.2%
The estimate for compound 3 lay 54.8 percentage points above the measured number; measured number below the stated range.
By their numbers in this assay, from the lowest: compounds 3 and 1 (each within the scatter of the next); then compound 2.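

In this assay, extending methyl to ethyl gives a number 63.6 percentage points lower from compound 2 to compound 3 (beyond the scatter). For the compounds shown here, this is the first measured pair to show what this kind of change does here: adding methyl in place of hydrogen on a saturated chain carbon bound to an aromatic carbon, a change of one carbon atom, is enough to cause a large loss of maximal response. No available evidence accounts for this drop.

As far as these compounds go, it remains open whether a longer chain, such as propyl, would stay as low as compound 3, or whether a methoxy group or an amine in the same place would restore the response. The compounds shown also cannot tell whether the same change would have a similar effect on a compound carrying bromine, as compound 1 does.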